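Swapping the Benzoyl Substituent in a Purinoceptor Antagonist Series

The source may report more compounds than this note shows. Statements on the series, on what has been measured and on what is new or still open speak of the compounds shown alone.

Of the compounds shown here, three have so far been measured in an assay on THP-1 cells for antagonist activity at P2X purinoceptor 7 (Homo sapiens), read by ELISA, with a stated time of 30 min; on this read-out lower numbers stand for stronger inhibition and higher numbers for weaker inhibition. Compound 1 `N#Cc1cccc(S(=O)(=O)Oc2ccc(-c3cncn3C3CCN(C(=O)c4ccc(Cl)c(C(F)(F)F)c4)CC3)cc2)c1` gives 4.28 nM. For the measured compounds named here, compound 2 `O=C(NC1CC1)c1cccc(S(=O)(=O)Oc2ccc(-c3cncn3C3CCN(C(=O)c4ccc(Cl)c(C(F)(F)F)c4)CC3)cc2)c1` gives 58 nM, and the single change between them produced the step of a 14-fold higher number from compound 1 to compound 2 (1.13 log units; beyond the scatter). Compound 3 `O=C(c1ccc(Cl)c(C(F)(F)F)c1)N1CCC(n2cncc2-c2ccc(OS(=O)(=O)c3cccc4cnccc34)cc2)CC1` gives 22 nM; it stands second highest of the three numbers, reached through a 5.1-fold higher number from compound 1 to compound 3 (0.71 log units; beyond the scatter) and through a 2.6-fold lower number from compound 2 to compound 3 (0.42 log units; beyond the scatter).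

Compound 4 `O=C(c1ccc([N+](=O)[O-])cc1)N1CCC(n2cncc2-c2ccc(OS(=O)(=O)c3cccc4cnccc34)cc2)CC1` differs from compound 3 in one place: 4-nitrophenyl in place of 4-chloro-3-(trifluoromethyl)phenyl on a carbonyl carbon. None of the three measured steps touches this part of the molecule; each of them exchanges the group on the sulfonyl sulfur, while the 4-chloro-3-(trifluoromethyl)phenyl is present unchanged in compound 1, compound 2 and compound 3 alike. The measured steps therefore offer no direct guide to the size or direction of this change, and the expectation must be held loosely. Since the group being removed is shared by every measured compound, the expected step of a 3.2-fold higher number from compound 3 to compound 4 (0.50 log units; beyond the scatter) is a rise in the number, somewhat beyond the scatter, with wide uncertainty on either side. Compound 4 is estimated to give about 70 nM, within a range from 15 nM to 300 nM.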

Compound 4, half-maximal inhibitory concentration: 8.29 nM
The estimate for compound 4 lay 8.4-fold (0.93 log units) above the measured number; the whole stated range lies above it.
By their numbers in this assay, from the lowest: compounds 1 and 4 (each within the scatter of the next); then compound 3; then compound 2.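

The group on the carbonyl carbon turns out to matter in its own right: with 4-nitrophenyl in place of 4-chloro-3-(trifluoromethyl)phenyl, this assay shows a 2.7-fold lower number from compound 3 to compound 4 (0.42 log units; beyond the scatter). Until now this group had been the same in every compound, so only the group on the sulfonyl sulfur had been seen to shift the number; the new step shows that, with isoquinolin-5-yl on the sulfonyl sulfur, neither the chlorine nor the trifluoromethyl group is needed to reach a lower number. The change swaps a group with no hydrogen-bond acceptors for one with 2 and also alters the heavy atom count, but nothing available ties the lower number to either difference or to any other feature of the exchange.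

One pair cannot say whether 4-nitrophenyl would give a similar step with 3-cyanophenyl or 3-(cyclopropylcarbamoyl)phenyl on the sulfonyl sulfur. It also leaves open how an unsubstituted phenyl would compare on the carbonyl carbon, or a phenyl carrying an amine or a carboxylic acid in place of the nitro group.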